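Aryl substituent change from compound 2 to compound 3

The source may report more compounds than this note shows. Statements on the series, on what has been measured and on what is new or still open speak of the compounds shown alone.

Two compounds of the shared core carry numbers in an assay on isolated protein for inhibition of 2-Hydroxyacid oxidase 2 (Homo sapiens), tested at 10 uM; a lower number here means a weaker effect, a higher number a stronger effect of the compound at the concentration tested. Compound 1 `Cc1n[nH]c(C(=O)O)c1Cc1ccccc1-c1ccc(F)cc1` gives 56% in this assay. Compound 2 `Cc1n[nH]c(C(=O)O)c1Cc1ccc(C(F)(F)F)cc1` gives 12% in this assay, the lowest of the two numbers; its nearest neighbour, compound 1, stands higher by a margin beyond the scatter. Going by the values given here, no step between measured compounds differing in one place is available, so the pair shows only what its two values show. Compound 3 `Cc1n[nH]c(C(=O)O)c1Cc1ccc(Oc2ccccc2)cc1` is not yet measured in this assay. It differs from compound 2 as follows: phenoxy in place of trifluoromethyl on an aromatic carbon The change sits on an aromatic carbon of a six-membered aromatic ring of carbon only. Without a measured step of this kind, a moderate step upward is expected in this assay, a number 23 percentage points higher from compound 2 to compound 3 (beyond the scatter), though one within the scatter cannot be excluded. The estimate for compound 3 in this assay is 35%, with a range from 10% to 65%.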

Compound 3, a percentage reported as inhibition, at one concentration (the size of the read-out at that concentration, not a potency): 43%
Beside the measured number, compound 3's estimate is 8 percentage points below it; the range from low to high includes it.
By their numbers in this assay, from the lowest: compound 2; then compound 3; then compound 1.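

In this assay, going by these compounds alone, phenoxy in place of trifluoromethyl on an aromatic carbon, para to a large group, gives a number 31 percentage points higher from compound 2 to compound 3 (beyond the scatter), the first step that isolates a single change. This position is therefore not indifferent to its substituent, and it accepts a group carrying a six-membered aromatic ring with a read-out well clear of that of the trifluoromethyl compound. Nothing available accounts for the size of this step, so it stands as an observation only.

On these data alone, it remains open whether the ether oxygen or the added ring carries the step, a question that phenyl or benzyl on the same aromatic carbon would address. Also open, as far as these compounds go, is how this assay responds to an amine or a carboxylic acid on the phenoxy ring.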